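Methoxy for bromo: from compound 3 to compound 4

The source may report more compounds than this note shows. Statements on the series, on what has been measured and on what is new or still open speak of the compounds shown alone.

Compound 1 `O=C(/C(=C\c1ccc(Cl)cc1Cl)S(=O)(=O)c1ccc(Br)cc1)c1ccc(Cl)cc1` gives 50000 nM
Compound 2 `COc1ccc(S(=O)(=O)/C(=C/c2ccc(Br)cc2)C(=O)c2ccc(Br)cc2)cc1` gives 6000 nM
Compound 3 `O=C(/C(=C\c1ccc(Cl)cc1Cl)S(=O)(=O)c1ccc(Br)cc1)c1ccc(Br)cc1` gives 10000 nM

All three numbers come from a functional assay on DU-145 cells (Homo sapiens) for inhibition, read by trypan blue exclusion, with a stated time of 96 h (a lower number here means a stronger inhibitor of growth, a higher number a weaker inhibitor of growth), and no others are at hand. Compound 3 lies within the usual scatter of compound 2 and clearly under compound 1. For the measured compounds named here, the one measured single-place step, a 5.0-fold lower number from compound 1 to compound 3 (0.70 log units; beyond the scatter), is modest and puts bromo in place of chloro on an aromatic carbon.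

Compound 4 `COc1ccc(S(=O)(=O)/C(=C/c2ccc(Cl)cc2Cl)C(=O)c2ccc(Br)cc2)cc1` departs from compound 3 in one place. The change is methoxy in place of bromo on an aromatic carbon and in words it is methoxy in place of bromo on an aromatic carbon.

Going by the values given here, no measured step makes this exchange. The bromo-for-chloro step is a different exchange and sets no direct size for it. Compound 2 does carry methoxy, and its value (6000 nM) lies within the scatter of compound 3 (10000 nM). The two differ in more than one place, however, so this is only weak support. No step beyond the scatter is therefore expected, in either direction. The estimated change is small, with a 1.3-fold lower number from compound 3 to compound 4 (0.10 log units; within the scatter) expected.

For compound 4 the estimated value is 8000 nM, with an expected range from 2500 nM to 25000 nM.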

Compound 4, concentration for 50% growth inhibition: 20000 nM
The estimate for compound 4 lay 2.5-fold (0.40 log units) below the measured number, within the range that was stated.
By their numbers in this assay, from the lowest: compounds 2, 3 and 4 (each within the scatter of the next, the first and the last beyond it); then compound 1.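

In this assay, methoxy in place of bromo, on an aromatic carbon para to a large group, can now be read directly, and the exchange from 4-bromophenyl to 4-methoxyphenyl gives a 2.0-fold higher number from compound 3 to compound 4 (0.30 log units; within the scatter) in a setting that keeps the 2,4-dichlorophenyl group. For the compounds shown here, with the 4-methoxyphenyl group held fixed, the other new step is the first reading of a change at the double-bonded chain carbon, where 2,4-dichlorophenyl in place of 4-bromophenyl gives a 3.3-fold higher number from compound 2 to compound 4 (0.52 log units; beyond the scatter) and, of the two new steps, only this one lies beyond the scatter. The compounds shown offer nothing that would explain why either step has the size it has.

From the compounds shown here alone, the methoxy exchange rests on a single pair, so it remains open whether it would read the same with 4-bromophenyl or another group at the double-bonded chain carbon. Going by these compounds, it is also open how this aromatic position would respond to an amine, a carboxylic acid or a longer chain such as ethoxy in place of methoxy or bromo.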